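The compounds below may be only part of what the source reports. "The series", "measured", "known", "first", "only" and "open" are said of these compounds alone.

Compound 2 `CC(C)c1ccc(OCC(=O)Nc2cccc(-c3nc4ncccc4o3)c2)cc1` carries a 4-isopropylphenyl ether on its amide arm. Going by the values given here, in an assay on brain for inhibition of Fatty-acid amide hydrolase 1 (Rattus norvegicus) (a lower number here means a stronger inhibitor, a higher number a weaker inhibitor), compound 2 gives 2100 nM, the lower of the two numbers measured so far. Among the compounds with values here, its nearest comparator is compound 1 `O=C(COc1ccccc1)Nc1cccc(-c2nc3ncccc3o2)c1`, which in this assay gives 18000 nM; the only step recorded, an 8.6-fold lower number from compound 1 to compound 2 (0.93 log units; beyond the scatter), came from the isopropyl in place of hydrogen on an aromatic carbon. Compound 3 `CCC/C=C/COCC(=O)Nc1cccc(-c2nc3ncccc3o2)c1` changes a different thing: hex-2-en-1-yl in place of 4-isopropylphenyl on an oxygen on a saturated carbon. Within the data shown here, no measured step speaks to the loss of the aromatic ring itself, so the recorded step from compound 1 to compound 2 bears on it only indirectly, showing that what sits on that ether end can move the number by a modest amount. For compound 3 a step of a 2.9-fold higher number from compound 2 to compound 3 (0.46 log units; beyond the scatter) is therefore expected, a weaker inhibitor than compound 2 but not far out of range. Compound 3 is estimated at 6000 nM, between 1500 nM and 25000 nM.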

Compound 3, half-maximal inhibitory concentration: 17000 nM
Estimate against measurement, compound 3: 2.8-fold (0.45 log units) below; low and high end bracket the measured number.
By their numbers in this assay, from the lowest: compound 2; then compounds 3 and 1 (each within the scatter of the next).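

In this assay the hex-2-en-1-yl in place of 4-isopropylphenyl gives an 8.1-fold higher number from compound 2 to compound 3 (0.91 log units; beyond the scatter) and so does not keep the lower number reached with the isopropyl-bearing ring. The other new step, a 1.1-fold lower number from compound 1 to compound 3 (0.02 log units; within the scatter) with hex-2-en-1-yl in place of phenyl, shows that the open chain and the plain phenyl cannot be told apart at this place, on an oxygen on a saturated carbon, leaving only the 4-isopropylphenyl of compound 2 apart from both. Nothing available here accounts for this pattern.

The compounds shown leave open whether the double bond of the hex-2-en-1-yl matters, which a saturated hexyl chain would test. They also leave open whether a longer chain or a cyclohexyl ring at this place would reach the number of compound 2.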